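The source may hold more compounds than are shown below. What is called first, only, known or untested is meant among the compounds shown, and "the series" means these compounds.

The measured compounds and their values in a functional assay on HL-60 cells (Homo sapiens) for antiproliferative activity, with a stated time of 24 h; on this read-out higher numbers stand for weaker inhibition and lower numbers for stronger inhibition:

compound 1, `NC(=O)c1c(NC(=O)c2ccc(C(F)(F)F)cc2)sc2c1CCN(Cc1ccccc1F)C2`: > 50000 nM
compound 2, `NC(=O)c1c(NC(=O)c2ccccc2Cl)sc2c1CCN(C(=S)Nc1ccccc1)C2`: 5940 nM
compound 3, `NC(=O)c1c(NC(=O)c2ccccc2Cl)sc2c1CCN(C(=S)Nc1ccccc1C(F)(F)F)C2`: 10600 nM

The value given for compound 1 is a limit of this assay rather than a number, as stated in the limit of > 50000 nM in this assay, at which 1 of the 3 values shown sits. Among the two numbers shown, compound 3 stands highest; its nearest neighbour is compound 2, and the step of a 1.8-fold higher number from compound 2 to compound 3 (0.25 log units; within the scatter) lies within the scatter. Compound 4, `NC(=O)c1c(NC(=O)c2ccccc2Cl)sc2c1CCN(C(=S)Nc1ccc(C(F)(F)F)cc1)C2`, differs from compound 3 by 4-(trifluoromethyl)phenyl in place of 2-(trifluoromethyl)phenyl on an amide-type nitrogen. Within the data shown here, the only measured step that bears on this change is a 1.8-fold higher number from compound 2 to compound 3 (0.25 log units; within the scatter), and that step concerns the introduction of the trifluoromethyl group on the aromatic carbon rather than a change in where it sits, so it gives little direct guidance; its size was within the scatter. On this basis compound 4 is expected to sit close to compound 3, with a step of a 1.2-fold lower number from compound 3 to compound 4 (0.07 log units; within the scatter) that is not expected to go beyond the scatter. The estimate for compound 4 in this assay is 9000 nM, with a range from 3500 nM to 25000 nM.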

Compound 4, half-maximal inhibitory concentration: 7590 nM
Compound 4: the middle estimate sits 1.2-fold (0.07 log units) above what was measured; the range from low to high includes it.
By their numbers in this assay, from the lowest: compounds 2, 4 and 3 (each within the scatter of the next). At a limit, above all of these: compound 1.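

In this assay, among these compounds, exchanging 2-(trifluoromethyl)phenyl for 4-(trifluoromethyl)phenyl on the amide-type nitrogen gives a 1.4-fold lower number from compound 3 to compound 4 (0.15 log units; within the scatter), the first direct reading of where this group sits, and the two placings cannot be told apart. Trifluoromethyl in place of hydrogen on the aromatic carbon gives a 1.3-fold higher number from compound 2 to compound 4 (0.11 log units; within the scatter), and a 1.8-fold higher number from compound 2 to compound 3 (0.25 log units; within the scatter) for the other placing, so neither placing separates from the compound that lacks the group. Nothing shown accounts for how small these steps are.

Going by these compounds, it remains open whether a different group on this aromatic ring, such as an amine, a methoxy group or a carboxylic acid, would produce a step beyond the scatter. On these data alone, it is also open how a carbonyl in place of the thiocarbonyl would read in this assay.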